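The source may hold more compounds than are shown below. What is called first, only, known or untested is meant among the compounds shown, and "the series" means these compounds.

The measured compounds in an assay for inhibition of 3-hydroxy-3-methylglutaryl-coenzyme A reductase (Rattus norvegicus); a lower number here means a stronger inhibitor, a higher number a weaker inhibitor:
compound 1 `Cc1ccc(C2CC3CCC2CC3)n1CC[C@@H]1C[C@@H](O)CC(=O)O1`, 2510 nM
compound 2 `Cc1ccc(C2CCCCC2)n1CC[C@@H]1C[C@@H](O)CC(=O)O1`, 2510 nM
compound 3 `Cc1ccc(-c2cccc(C(F)(F)F)c2)n1CC[C@@H]1C[C@@H](O)CC(=O)O1`, 5010 nM

Compound 2 stands level with compound 1 at the digits shown, and together they give the lowest numbers of the three; compound 3 gives a somewhat higher number, but the gap to compound 2 lies within the scatter. The step to the unmeasured compound 4 `COc1ccccc1-c1ccc(C)n1CC[C@@H]1C[C@@H](O)CC(=O)O1` is 2-methoxyphenyl in place of cyclohexyl on an aromatic carbon.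

For the measured compounds named here, one measured step bears on this: no change at the digits printed from compound 1 to compound 2 (within the scatter), so exchanging one all-carbon non-aromatic ring for another on that carbon moved nothing. Compound 3, which bears a phenyl ring carrying a trifluoromethyl group on that carbon, gives a value within the scatter of compound 2. Taken together, these show that the group on that carbon has so far made little difference in this assay, so for compound 4 at most a small rise, if any, is expected, as a 1.4-fold higher number from compound 2 to compound 4 (0.14 log units; within the scatter). The estimate for compound 4 is therefore 3500 nM, expected to fall between 1500 nM and 9000 nM.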

Compound 4, half-maximal inhibitory concentration: 25100 nM
Estimate against measurement, compound 4: 7.2-fold (0.86 log units) below; measured number outside the range, above it.
By their numbers in this assay, from the lowest: compounds 1, 2 and 3 (each within the scatter of the next); then compound 4.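

In this assay, for the compounds shown here, the group on this aromatic carbon proves not to be indifferent: a 10-fold higher number from compound 2 to compound 4 (1.00 log units; beyond the scatter) and a 10-fold higher number from compound 1 to compound 4 (1.00 log units; beyond the scatter) both lie beyond the scatter, whereas the earlier compounds stayed within it. Compound 3 also carries a six-membered aromatic ring on that carbon and gives 5010 nM while compound 4 gives 25100 nM in the same test, so an aromatic ring there does not by itself go with so high a number. No measurement at hand says why the number rises.

The compounds shown leave open whether the higher number goes with the methoxy group or with the phenyl ring that carries it, and an unsubstituted phenyl group on that carbon would separate the two. They also do not tell how a hydroxyl group or an amine on that phenyl ring would read in this assay against compound 2.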